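This account rests on a few compounds, and the source may have more. Where it says the series, first, only, none or still open, it means among the compounds named here.

In a functional assay on C6 cells (Rattus norvegicus) for cytotoxicity, read by MTT assay, with a stated time of 24 h, tested at 12 ug/mL (a lower number here means a stronger effect, a higher number a weaker effect of the compound at the concentration tested), compound 2 `COc1ccc(-c2cs/c(=N/NC(=O)CSc3ncccn3)n2-c2ccccc2)cc1` gives 78.4%, nominally the higher of the two numbers recorded so far, but only by a margin within the usual scatter. The other measured compound, compound 1 `O=C(CSc1ncccn1)N/N=c1/scc(-c2ccc(Br)cc2)n1-c1ccccc1`, gives 72.1% in this assay. Among the measured compounds shown here, the single measured step, a number 6.3 percentage points higher from compound 1 to compound 2 (within the scatter), exchanges one group on the same aromatic carbon and stays within the scatter. Compound 3 `O=C(CSc1ncccn1)N/N=c1/scc(-c2ccc(F)cc2)n1-c1ccccc1` has not yet been measured. Its structure differs from that of compound 2 by fluoro in place of methoxy on an aromatic carbon. Because a number 6.3 percentage points higher from compound 1 to compound 2 (within the scatter) stayed within the scatter, another exchange at this same aromatic carbon is expected to move the number little, in no clear direction. Compound 3 is therefore expected to give 75% in this assay, with a range from 60% to 90%. That corresponds to an expected step of a number 3.4 percentage points lower from compound 2 to compound 3 (within the scatter).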

Compound 3, a percentage reported as activity, at one concentration (the size of the read-out at that concentration, not a potency): 77.4%
Estimate against measurement, compound 3: 2.4 percentage points below, within the range that was stated.
By their numbers in this assay, from the lowest: compounds 1, 3 and 2 (each within the scatter of the next).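

Fluoro is a third group on this aromatic carbon in this assay, and replacing methoxy with it brings a number 1 percentage points lower from compound 2 to compound 3 (within the scatter), while replacing bromo with it brings a number 5.3 percentage points higher from compound 1 to compound 3 (within the scatter). Bromo, methoxy and fluoro on this carbon therefore all lie within the scatter of one another, something a single step could not show, and the read-out does not tell these three groups apart at the concentration tested. No measurement is available that could explain this result.

The compounds shown leave open whether a different kind of group on this carbon, such as an amine or a carboxylic acid, would move the number beyond the scatter. Also open, going by these compounds, is whether an exchange elsewhere in the shared core would do so.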